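Moving a Methoxy Group on the Sulfonyl Aryl Ring

A few compounds are considered here, and "the series" means these few. Any claim that something is new, unique, unknown or untested is made for them only; others in the source may bear on it.

Compound 1 `COc1ccc(S(=O)(=O)NCCN2CCC(CCC(=O)c3cc(Cl)c(N)cc3OC)CC2)cc1Cl` gives 85% in an assay on HEK293 cells for displacement of a labelled ligand from 5-hydroxytryptamine receptor 6 (Homo sapiens), with a stated time of 60 min, tested at 1 uM, in the presence of a further agent that is not named here; on this read-out lower numbers stand for a weaker effect and higher numbers for a stronger effect at the one concentration tested.
Compound 2 `COc1cc(N)c(Cl)cc1C(=O)CCC1CCN(CCNS(=O)(=O)c2ccc(C)cc2)CC1` gives 15% in this assay.
Compound 3 `COc1ccc(S(=O)(=O)NCCN2CCC(CCC(=O)c3cc(Cl)c(N)cc3OC)CC2)cc1OC` gives 58% in this assay.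

Among these three, compound 3 stands second, beyond the scatter below compound 1 and beyond the scatter above compound 2. Compound 4 `COc1ccc(S(=O)(=O)NCCN2CCC(CCC(=O)c3cc(Cl)c(N)cc3OC)CC2)c(OC)c1` has not been measured. It differs from compound 3 in one place: 2,4-dimethoxyphenyl in place of 3,4-dimethoxyphenyl on a sulfonyl sulfur.

For the measured compounds named here, none of the measured steps moves a methoxy group from one position to another on this ring. The steps that exist change what sits on the sulfonyl aryl ring altogether: a number 70 percentage points lower from compound 1 to compound 2 (beyond the scatter), a number 43 percentage points higher from compound 2 to compound 3 (beyond the scatter) and a number 27 percentage points lower from compound 1 to compound 3 (beyond the scatter). These show that this ring is sensitive to substitution, but they give no direction for the present change, since both compound 3 and compound 4 carry two methoxy groups. Compound 4 is therefore expected to stay close to compound 3, with a step of a number 8 percentage points lower from compound 3 to compound 4 (within the scatter) and a wide range, and its value in this assay is estimated at 50%, between 20% and 80%.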

Compound 4, a percentage reported as inhibition, at one concentration (the size of the read-out at that concentration, not a potency): 45%
Estimate against measurement, compound 4: 5 percentage points above; the range from low to high includes it.
By their numbers in this assay, from the lowest: compound 2; then compound 4; then compound 3; then compound 1.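

For the compounds shown here, compound 4 gives the first measured step on this ring in which the atoms stay the same and only their arrangement changes: the 2,4-dimethoxyphenyl group in place of the 3,4-dimethoxyphenyl group on the sulfonyl sulfur gives a number 13 percentage points lower from compound 3 to compound 4 (beyond the scatter) in this assay, so the arrangement of the two methoxy groups matters by itself, though the step is modest. The 2,4-dimethoxyphenyl group still stands clear of the 4-methylphenyl group (a number 30 percentage points higher from compound 2 to compound 4 (beyond the scatter)) and well short of the 3-chloro-4-methoxyphenyl group (a number 40 percentage points lower from compound 1 to compound 4 (beyond the scatter)). Nothing available bears on the cause of these steps.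

As far as these compounds go, whether a nitrile, an amine or a carboxylic acid on this ring would reach the number of compound 1 stays open. Each of these four compounds was read at one concentration only, and the numbers speak only of a stronger or weaker effect at that concentration.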